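The compounds below may be only part of what the source reports. "The series", "measured", "known", "first", "only" and "open" are said of these compounds alone.

Measured so far:
compound 1, `Nc1scc(CN2CCN(c3ccccc3)CC2)c1C(=O)c1ccc(Cl)cc1`, 1.9 nM
compound 2, `Nc1scc(CN2CCN(c3ccc(Cl)cc3)CC2)c1C(=O)c1ccc(Cl)cc1`, 1.8 nM
compound 3, `Nc1scc(CN2CCN(c3ccccn3)CC2)c1C(=O)c1ccc(Cl)cc1`, 1.7 nM

The three compounds share one core and differ only in the group carried by the ring nitrogen of the six-membered non-aromatic ring. In an assay on CHO cells for displacement of a labelled ligand from adenosine receptor A1 (Homo sapiens) (a higher number here means weaker binding, a lower number tighter binding), compound 3 sits alongside the other two: the step of a 1.1-fold lower number from compound 1 to compound 3 (0.05 log units; within the scatter) and the step of a 1.1-fold lower number from compound 2 to compound 3 (0.02 log units; within the scatter) are both within the scatter, as is a 1.1-fold lower number from compound 1 to compound 2 (0.02 log units; within the scatter). So far, then, swapping the group on that nitrogen has left the number where it was.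

Compound 4, `Nc1scc(CN2CCN(c3ncccn3)CC2)c1C(=O)c1ccc(Cl)cc1`, takes this one step further: pyrimidin-2-yl in place of pyridin-2-yl on an amine nitrogen in a ring. The three measured steps all concern exchanges of the aromatic group on the same ring nitrogen, and none of them moved the number beyond the scatter. On that basis no step beyond the scatter is expected in this assay, in either direction, so compound 4 is expected to give 2 nM, with a range from 0.9 nM to 4.5 nM. The expected step of a 1.2-fold higher number from compound 3 to compound 4 (0.07 log units; within the scatter) is therefore estimated to be small.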

Compound 4, dissociation constant: 1.7 nM
The estimate for compound 4 lay 1.2-fold (0.07 log units) above the measured number; the range from low to high includes it.
By their numbers in this assay, from the lowest: compounds 3, 4, 2 and 1 (each within the scatter of the next).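

In this assay, pyrimidin-2-yl, with 2 hydrogen-bond acceptors where pyridin-2-yl has 1, gives no change at the digits printed from compound 3 to compound 4 (within the scatter). The comparisons with the other two groups read the same way, with a 1.1-fold lower number from compound 2 to compound 4 (0.02 log units; within the scatter) and a 1.1-fold lower number from compound 1 to compound 4 (0.05 log units; within the scatter), so this ring nitrogen now carries four different six-membered aromatic rings, including one with 2 hetero atoms, and all four compounds remain within the scatter of each other. No available evidence explains why these exchanges leave the number in place.

From the compounds shown here alone, all four groups are six-membered aromatic rings, so it remains open whether a non-aromatic group on this nitrogen, such as methyl, cyclohexyl or acetyl, would hold the number as well. Going by these compounds, it is also open whether a benzyl group, which sets the aromatic ring one carbon further from this nitrogen, would do the same.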